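The source may hold more compounds than are shown below. What is called first, only, known or untested is meant among the compounds shown, and "the series" means these compounds.

Notes on the series. Compound 1 `O=C(Nc1n[nH]c2c1CN(C(=O)c1ccccc1)C2)c1ccc(F)cc1` gives 3190 nM in a functional assay on HCT-116 cells (Homo sapiens) for cytotoxicity, read by sulforhodamine B assay, with a stated time of 48 h; a higher number here means a weaker inhibitor, a lower number a stronger inhibitor. Compound 2 `COc1ccc(C(=O)Nc2n[nH]c3c2CN(C(=O)c2ccccc2)C3)cc1` gives 13600 nM in this assay. The change between them is methoxy in place of fluoro on an aromatic carbon and the step is a 4.3-fold higher number from compound 1 to compound 2 (0.63 log units; beyond the scatter). Compound 3 `CCCCNC(=O)N1Cc2c(NC(=O)c3ccc(F)cc3)nn(C(=O)C3CC3)c2C1` gives 23300 nM in this assay; it stands highest of the three numbers, with compound 2 nearest and within the scatter, and compound 1 furthest and beyond it. The difference between the core of compound 1 and the core of compound 3 is not broken down here.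

Compound 4 `CCCCNC(=O)N1Cc2c(NC(=O)c3ccc(OC)cc3)nn(C(=O)C3CC3)c2C1` remains to be measured in this assay. Its change from compound 3 is methoxy in place of fluoro on an aromatic carbon, the same change as from compound 1 to compound 2, at a place described in the same words. For compound 4 the step is expected to be a 3.9-fold higher number from compound 3 to compound 4 (0.59 log units; beyond the scatter), about the size of the earlier step, because that step gave a 4.3-fold higher number from compound 1 to compound 2 (0.63 log units; beyond the scatter). Compound 4 is therefore expected near 90000 nM, between 35000 nM and 230000 nM, with a fair chance that only a limit is reported.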

Compound 4, half-maximal inhibitory concentration: 65500 nM
The estimate for compound 4 lay 1.4-fold (0.14 log units) above the measured number; measured number inside the range.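

In this assay the methoxy for fluoro change gives a 2.8-fold higher number from compound 3 to compound 4 (0.45 log units; beyond the scatter) and points the same way as on the core of compound 1, with the two steps not told apart by the scatter: the same change on two cores in this assay, a 4.3-fold higher number (0.63 log units; beyond the scatter) from compound 1 to compound 2 and a 2.8-fold higher number (0.45 log units; beyond the scatter) from compound 3 to compound 4, 1.5-fold (0.18 log units) apart, within the scatter of two such steps. On these two cores the change therefore carries over in direction and, within the scatter, in size, and no compound shown goes against this. Among the compounds shown here, the finding rests on only two matched pairs in this assay and does not show that the step would hold on a further core, nor does it explain why the number rises.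

Still open, on these data alone, is how a chloro group, a hydroxyl group or a dimethylamino group would behave in place of fluoro on either core. Also open, as far as these compounds go, is whether the step would persist on a core carrying an amine or a carboxylic acid in place of the butyl chain of compound 3.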